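A few compounds are considered here, and "the series" means these few. Any claim that something is new, unique, unknown or untested is made for them only; others in the source may bear on it.

In an ADME assay on L6 cells (Rattus norvegicus) for inhibition, read by resazurin assay, with a stated time of 72 h (on this read-out higher numbers stand for weaker inhibition and lower numbers for stronger inhibition), compound 1 `CC(=O)O[C@@H]1[C@H](OC(C)=O)[C@@H](C[S+](C)[O-])O[C@H]1n1cnc2c(N)nc(Cl)nc21` gives 168000 nM and compound 3 `CS(=O)(=O)C[C@H]1O[C@@H](n2cnc3c(N)nc(Cl)nc32)[C@H](O)[C@@H]1O` gives 156000 nM, two values within the scatter of each other. Compound 2 `CS(=O)(=O)C[C@H]1O[C@@H](n2cnc3c(N)nc(F)nc32)[C@H](O)[C@@H]1O` gives 5000 nM, far lower than either. Compound 4 `CC(=O)NC[C@H]1O[C@@H](n2cnc3c(N)nc(Cl)nc32)[C@H](OC(C)=O)[C@@H]1OC(C)=O` has not yet been measured and differs from compound 1 at one place: a group of 4 heavy atoms (2 carbon, 1 nitrogen, 1 oxygen; no ring) in place of a group of 3 heavy atoms (1 carbon, 1 oxygen, 1 sulfur; no ring), on a saturated chain carbon bound to a saturated ring carbon. Acetamido enters on a saturated chain carbon bound to a saturated ring carbon.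

For the measured compounds named here, the only measured single-place step, a 31-fold higher number from compound 2 to compound 3 (1.49 log units; beyond the scatter), is large, but it concerns the halogen on an aromatic carbon. Compound 1 and compound 4 both carry chloro there, so that step does not transfer directly. Going by the values given here, no measured step covers the exchange at the chain carbon, so the size of its contribution is unknown. With nothing to indicate a move, no shift beyond the scatter is expected in this assay, and the range is kept wide. The estimate corresponds to an expected 1.4-fold lower number from compound 1 to compound 4 (0.15 log units; within the scatter). For compound 4 the expected value is 120000 nM, with an estimated range of 40000 nM to 250000 nM.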

Compound 4, half-maximal inhibitory concentration: 190000 nM
The estimate for compound 4 lay 1.6-fold (0.20 log units) below the measured number; measured number inside the range.
By their numbers in this assay, from the lowest: compound 2; then compounds 3, 1 and 4 (each within the scatter of the next).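

In this assay, the saturated chain carbon bound to a saturated ring carbon takes acetamido in place of the sulfur-bearing group of compound 1 with no change beyond the scatter: a 1.1-fold higher number from compound 1 to compound 4 (0.05 log units; within the scatter). For the compounds shown here, the hydrogen-bond donor that acetamido adds, absent from the group that leaves, therefore comes with no readable shift on this chloro background, whereas the halogen exchange remains the only large step so far, with a 31-fold higher number from compound 2 to compound 3 (1.49 log units; beyond the scatter). No available evidence bears on the reason for this result.

Going by these compounds, whether acetamido behaves the same way with fluoro on the aromatic carbon, where compound 2 gives 5000 nM, remains open. Also open, on these data alone, is whether an amine, a carboxylic acid or a longer chain on this chain carbon would move the number beyond the scatter.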